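Swapping Nitro for Methoxy on a Core with a Higher Number

This account rests on a few compounds, and the source may have more. Where it says the series, first, only, none or still open, it means among the compounds named here.

Measured so far:
compound 1 `CCCc1n[nH]c2c(=O)n(NC(=O)c3ccccc3)c(-c3cccc([N+](=O)[O-])c3)nc12` gives 22.9% in a functional assay on SK-MEL-2 cells (Homo sapiens) for cytotoxicity, read by sulforhodamine B assay, with a stated time of 2 days, tested at 100 uM; a higher number here means more inhibition at the concentration tested (going by the name of the read-out), a lower number less inhibition
compound 2 `CCCc1n[nH]c2c(=O)n(NC(=O)c3ccccc3)c(-c3cccc(OC)c3)nc12` gives 16.7% in this assay
compound 3 `O=C(Nn1c(-c2cccc([N+](=O)[O-])c2)nc2c(-c3ccc(Cl)cc3)n[nH]c2c1=O)c1ccccc1` gives 89% in this assay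

Compound 4 `COc1cccc(-c2nc3c(-c4ccc(Cl)cc4)n[nH]c3c(=O)n2NC(=O)c2ccccc2)c1` has not yet been measured. It differs from compound 3 in one place: methoxy in place of nitro on an aromatic carbon. The same change has already been made once among the measured compounds, from compound 1 to compound 2: methoxy in place of nitro on an aromatic carbon. There it gave a number 6.2 percentage points lower from compound 1 to compound 2 (within the scatter), so the two values are not distinguishable within the usual scatter.

Compound 3 stands on a different core from compound 1, and the two cores differ by 4-chlorophenyl in place of propyl on an aromatic carbon. That change made a large difference: a number 66.1 percentage points higher from compound 1 to compound 3 (beyond the scatter). Compound 4 keeps the core of compound 3.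

Since the nitro-to-methoxy change sits at the same place on the same kind of ring in both pairs, the step from compound 3 to compound 4 is expected to be small as well, about a number 6 percentage points lower from compound 3 to compound 4 (within the scatter), resting on the step seen from compound 1 to compound 2. Compound 4 is therefore estimated at 83%, with a likely range from 65% to 95% in this assay.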

Compound 4, a percentage reported as inhibition, at one concentration (the size of the read-out at that concentration, not a potency): 84.9%
The estimate for compound 4 lay 1.9 percentage points below the measured number; measured number inside the range.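

On the core of compound 3, methoxy in place of nitro gave a number 4.1 percentage points lower from compound 3 to compound 4 (within the scatter) in this assay, which matches what the same swap did on the core of compound 1: the same change on two cores in this assay, a number 6.2 percentage points lower (within the scatter) from compound 1 to compound 2 and a number 4.1 percentage points lower (within the scatter) from compound 3 to compound 4, 2.1 percentage points apart, within the scatter of two such steps

Read the other way, 4-chlorophenyl in place of propyl gave a number 68.2 percentage points higher from compound 2 to compound 4 (beyond the scatter), so this large step appears with either group on the ring: the same change on two cores in this assay, a number 66.1 percentage points higher (beyond the scatter) from compound 1 to compound 3 and a number 68.2 percentage points higher (beyond the scatter) from compound 2 to compound 4, 2.1 percentage points apart, within the scatter of two such steps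

Across these four compounds, then, the two changes carry from one core to the other, with the swap of nitro for methoxy leaving the read-out indistinguishable on both cores and the core change accounting for the large steps, but this rests on only two pairs of steps and says nothing about why the numbers behave this way.

The compounds shown leave open whether an amine or a carboxylic acid in place of nitro would fit the same picture. They also leave open whether a longer chain in place of propyl, or a phenyl ring without the chlorine, would fall near the low or the high values.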